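Working notes: replacing 4-chlorophenyl in compound 1

The compounds below may be only part of what the source reports. "The series", "measured", "known", "first", "only" and "open" are said of these compounds alone.

- compound 1 `CC(=O)c1ccc(NC(=O)Cn2nc(-c3ccc(Cl)cc3)nc2N)cc1` gives 16.5%
- compound 2 `C/C(=N\O)c1ccc(NC(=O)Cn2nc(-c3ccc(Cl)cc3)nc2N)cc1` gives 33%
- compound 3 `COc1cc(-c2nc3sc(-c4ccccc4)cn3n2)cc(OC)c1OC` gives 44%

In a functional assay on MOLT-4 cells (Homo sapiens) for inhibition, read by sulforhodamine B assay, with a stated time of 48 h, tested at 10 uM (on this read-out lower numbers stand for less inhibition of growth and higher numbers for more inhibition of growth at the one concentration tested), compound 1 gives 16.5% as the lowest of the three numbers, with compound 2 and compound 3 both beyond the scatter above it. Compound 4 `CC(=O)c1ccc(NC(=O)Cn2nc(C(F)(F)F)nc2N)cc1` departs from compound 1 at one place: trifluoromethyl in place of 4-chlorophenyl on an aromatic carbon. Within the data shown here, the one measured step, a number 16.5 percentage points higher from compound 1 to compound 2 (beyond the scatter), involves a different group, so it offers only a guide to size. Among the measured compounds shown here, no measured step touches the 4-chlorophenyl group. A modest fall in this assay is expected, or none beyond the scatter. The expected step is a number 4.5 percentage points lower from compound 1 to compound 4 (within the scatter) and nothing firmer is available. For compound 4 the estimate is 12% with 2% to 28% as the expected range.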

Compound 4, percent growth inhibition at one concentration: 7.46%
Estimate against measurement, compound 4: 4.5 percentage points above; the range from low to high includes it.
By their numbers in this assay, from the lowest: compounds 4 and 1 (each within the scatter of the next); then compound 2; then compound 3.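

In this assay, among these compounds, the first change at this position gives a number 9 percentage points lower from compound 1 to compound 4 (within the scatter). Losing the six-membered aromatic ring of 4-chlorophenyl in favour of trifluoromethyl therefore has no effect here that can be told from the scatter, so this ring is not shown to matter for the number at the one concentration tested. Nothing available bears on why this is so.

Still open, going by these compounds, is whether an amine, a methyl group or an unsubstituted phenyl at this position would shift the number. Also open, on these data alone, is whether trifluoromethyl would behave alike on the core of compound 2.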